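Cytotoxicity notes: from compound 3 to compound 4

The compounds below may be only part of what the source reports. "The series", "measured", "known", "first", "only" and "open" are said of these compounds alone.

Compound 1 `O=C(O)c1cccn1-c1ccc2c(c1)B(O)OC2`, compound 2 `O=C(NCc1ccccc1)c1cccn1-c1ccc2c(c1)B(O)OC2` and compound 3 `O=C(c1ccn(-c2ccc3c(c2)B(O)OC3)c1)c1ccc(Cl)cc1Cl` share one core. In an ADME assay on L929 cells (Mus musculus) for cytotoxicity, read by resazurin assay, with a stated time of 72 h (a higher number here means a weaker inhibitor, a lower number a stronger inhibitor), compound 1 reaches only the assay limit of > 10 ug/mL, which is not a number. Compound 2 likewise sits at the limit of > 10 ug/mL in this assay. Compound 3 stands at the limit of > 10 ug/mL in this assay, so only a range is known for it. The step that the two limits leave unreadable from compound 1 to compound 2 therefore cannot be read. Every value shown sits at the limit of > 10 ug/mL in this assay, at which 3 of the 3 values shown sit. Compound 4 `O=C(c1cccc(Cl)c1)c1ccn(-c2ccc3c(c2)B(O)OC3)c1` differs from compound 3 by 3-chlorophenyl in place of 2,4-dichlorophenyl on a carbonyl carbon. Among the measured compounds shown here, no measured step bears on this change, and with all three values at the limit no shift beyond scatter is expected. Compound 4 is expected to remain near the limit, estimated at 20 ug/mL with a range of 7 ug/mL to 60 ug/mL, an expected step that the limit leaves unreadable from compound 3 to compound 4.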

Compound 4, half-maximal inhibitory concentration: > 10 ug/mL
Compound 4: only a limit was reported; the forecaster's own chance of this, stated with the estimate: 85%; the middle value is on the limit's open side.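

Compound 4 gives > 10 ug/mL in this assay, a limit and not a number. Among the compounds shown here, no new step can therefore be read from compound 3 to compound 4. The actual cytotoxic concentration of each compound stays open, since all sit at one limit: the limit of > 10 ug/mL in this assay, at which 4 of the 4 values shown sit.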